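Methyl on the distal phenyl of a thiosemicarbazide series

The source may report more compounds than this note shows. Statements on the series, on what has been measured and on what is new or still open speak of the compounds shown alone.

Three compounds of one shared core have been run in a functional assay on MCF7 cells (Homo sapiens) for inhibition, read by colorimetric assay and MTT assay, with a stated time of 72 h; on this read-out higher numbers stand for weaker inhibition and lower numbers for stronger inhibition. Compound 1 `O=C(NNC(=S)Nc1csc(-c2ccccc2)c1)c1ccc(O)cc1` gives 78000 nM in this assay. Compound 2 `Cc1ccc(-c2cc(NC(=S)NNC(=O)c3ccc(O)cc3)cs2)cc1` differs from compound 1 by methyl in place of hydrogen on an aromatic carbon. In this assay compound 2 gives 42000 nM; this single change made a 1.9-fold lower number from compound 1 to compound 2 (0.27 log units; within the scatter). Compound 3 `COc1ccc(C(=O)NNC(=S)Nc2csc(-c3ccccc3)c2)cc1OC` carries a different core, and the difference between the two cores is not broken down here. In this assay compound 3 gives 21000 nM, the lowest of the three numbers, though its gap to compound 2 is within the scatter and only its gap to compound 1 is beyond it.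

Compound 4 `COc1ccc(C(=O)NNC(=S)Nc2csc(-c3ccc(C)cc3)c2)cc1OC` has not yet been measured. It differs from compound 3 by methyl in place of hydrogen on an aromatic carbon, the same change as that from compound 1 to compound 2, at the same place. Among the measured compounds shown here, the one measured instance of this change gave a within-scatter step, so the expectation for compound 4 rests on compound 3 and on the size of the earlier step of a 1.9-fold lower number from compound 1 to compound 2 (0.27 log units; within the scatter). The step from compound 3 to compound 4 is expected to be a 1.5-fold lower number from compound 3 to compound 4 (0.18 log units; within the scatter) in this assay, with no firm direction because the earlier step of a 1.9-fold lower number from compound 1 to compound 2 (0.27 log units; within the scatter) sits inside the scatter. For compound 4 the estimated value in this assay is 14000 nM, within a range from 5000 nM to 40000 nM.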

Compound 4, half-maximal inhibitory concentration: 11000 nM
Estimate against measurement, compound 4: 1.3-fold (0.10 log units) above; the range from low to high includes it.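

In this assay the phenyl to 4-methylphenyl change gives a 1.9-fold lower number from compound 3 to compound 4 (0.28 log units; within the scatter). Set beside the earlier instance, the change carries over between the two cores with a step of matching size: the same change on two cores in this assay, a 1.9-fold lower number (0.27 log units; within the scatter) from compound 1 to compound 2 and a 1.9-fold lower number (0.28 log units; within the scatter) from compound 3 to compound 4, 1.0-fold (0.01 log units) apart, within the scatter of two such steps. Among the compounds shown here, this agreement rests on only two matched pairs, and each step lies within the scatter taken alone, so it does not establish a real gain from the methyl on either core, nor does it predict the step on any further core.

Only hydrogen and methyl appear at this place on the six-membered aromatic ring, which leaves open whether a longer chain such as propyl, an amine or a carboxylic acid there would give a step beyond the scatter. Also open, from the compounds shown here alone, is whether the match between the two steps would hold on a third core or in any read-out other than this assay.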